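Swapping a methoxyphenoxyethyl tail for an azide

This account rests on a few compounds, and the source may have more. Where it says the series, first, only, none or still open, it means among the compounds named here.

Measured compounds:
compound 1, `O=C(OCC1CCCN(C(=O)CCc2ccccc2)C1)c1ccccc1-c1ccccc1`: 5600 nM; 6030 nM (2 entries)
compound 2, `COc1ccc(OCCCCCN2CCCC(COC(=O)c3ccccc3-c3ccccc3)C2)cc1`: 14500 nM

Both compounds share the same core and differ in the group attached to the ring nitrogen. In an in vitro functional assay on HEK ts201 cells for antagonist activity at Neuronal acetylcholine receptor; alpha4/beta2 (Homo sapiens), read by fluorescence and calcium flux (a lower number here means a stronger inhibitor, a higher number a weaker inhibitor), compound 1 gives 5600 nM; 6030 nM (2 entries), with its repeat entries summarised as the several entries of compound 1 in this assay, 5600 nM; 6030 nM (2 entries). Within the data shown here, compound 2 gives 14500 nM in this assay; that is the only number it has, alongside one further entry that carries no number, so its standing rests on a single figure.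

Compound 3, `[N-]=[N+]=NCCCN1CCCC(COC(=O)c2ccccc2-c2ccccc2)C1`, is not yet measured. It differs from compound 2 as azido in place of 2-(4-methoxyphenoxy)ethyl on a saturated chain carbon, three bonds along the chain from an amine nitrogen in a ring. Among the measured compounds shown here, with no measured step of this kind to lean on, the change is expected to be small, at most a modest gain, and possibly nothing beyond the scatter, since compound 1 with its shorter side group gives 5600 nM; 6030 nM (2 entries) in this assay. The step from compound 2 to compound 3 is estimated as a 1.5-fold lower number from compound 2 to compound 3 (0.16 log units; within the scatter). Compound 3 is expected to give 10000 nM in this assay, within 3500 nM to 35000 nM.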

Compound 3, half-maximal inhibitory concentration: 4270 nM
Compound 3: the middle estimate sits 2.3-fold (0.37 log units) above what was measured, within the range that was stated.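

In this assay, among these compounds, this is the first measured step at this position: replacing 2-(4-methoxyphenoxy)ethyl with azido gives a 3.4-fold lower number from compound 2 to compound 3 (0.53 log units; beyond the scatter). The aromatic ring and ether oxygens of the departing group are therefore not needed to keep this level of inhibition, and the much smaller azido group does modestly better. Compound 3 gives 4270 nM, which puts it close to compound 1, a compound with a quite different group on the ring nitrogen: the several entries of compound 1 in this assay, 5600 nM; 6030 nM (2 entries)

The compounds shown cannot separate the effect of losing the long tail from any contribution of the azido group itself. An amine, a hydroxyl or a plain propyl chain on the ring nitrogen would help tell these apart, and so would a longer chain ending in azido.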